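Aryl replacement at the shared core: compound 3 to compound 4

The compounds below may be only part of what the source reports. "The series", "measured", "known", "first", "only" and "open" are said of these compounds alone.

Measured compounds:
- compound 1 `O=Cc1ccc(-c2cn3ccnc3c(-c3ccc4ncn(C5CCCCC5)c4c3)n2)cc1`: 82.5%
- compound 2 `c1cn2cc(-c3ccsc3)nc(-c3ccc4ncn(C5CCCCC5)c4c3)c2n1`: 37.9%
- compound 3 `c1csc(-c2cn3ccnc3c(-c3ccc4ncn(C5CCCCC5)c4c3)n2)c1`: 52.3%

In a functional assay on RPMI-8226 cells (Homo sapiens) for inhibition, read by sulforhodamine B assay, with a stated time of 48 h, tested at 10 uM (on this read-out higher numbers stand for more inhibition at the one concentration tested (going by the name of the read-out) and lower numbers for less inhibition), compound 1 gives 82.5%, compound 2 gives 37.9% and compound 3 gives 52.3%. Compound 3 stands second of the three, beyond the scatter below compound 1 and beyond the scatter above compound 2, with a number 30.2 percentage points lower from compound 1 to compound 3 (beyond the scatter) and a number 14.4 percentage points higher from compound 2 to compound 3 (beyond the scatter).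

Compound 4 `FC(F)(F)c1cccc(-c2cn3ccnc3c(-c3ccc4ncn(C5CCCCC5)c4c3)n2)c1` is not yet measured. The change from compound 3 is 3-(trifluoromethyl)phenyl in place of thiophen-2-yl on an aromatic carbon.

Within the data shown here, two measured steps bear on it. Both exchanges of the 4-formylphenyl for a thiophenyl lowered the read-out by a large amount, a number 44.6 percentage points lower from compound 1 to compound 2 (beyond the scatter) and a number 30.2 percentage points lower from compound 1 to compound 3 (beyond the scatter), so the group at this position matters strongly to this assay. The only six-membered aromatic ring seen at this position, in compound 1, gave the highest number, but it carried a hydrogen-bond acceptor that the incoming 3-(trifluoromethyl)phenyl lacks, and no other ring of that kind has been measured, so the step cannot be pinned closely. A rise beyond the scatter from compound 3 is expected, though probably not reaching compound 1. The expected step is a number 9.7 percentage points higher from compound 3 to compound 4 (within the scatter). Compound 4 is estimated at 62%, within 38% to 85%.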

Compound 4, a percentage reported as inhibition, at one concentration (the size of the read-out at that concentration, not a potency): 32.1%
Estimate against measurement, compound 4: 29.9 percentage points above, and the stated range ends above it.
By their numbers in this assay, from the lowest: compounds 4 and 2 (each within the scatter of the next); then compound 3; then compound 1.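

In this assay, a six-membered aromatic ring of carbon only does not by itself secure a high number at this position: 3-(trifluoromethyl)phenyl gives a number 20.2 percentage points lower from compound 3 to compound 4 (beyond the scatter) and a number 50.4 percentage points lower from compound 1 to compound 4 (beyond the scatter), so compound 4 goes against any reading that compound 1 stands highest through its ring type alone. The step to the other thiophene, a number 5.8 percentage points lower from compound 2 to compound 4 (within the scatter), shows no separation between 3-(trifluoromethyl)phenyl and thiophen-3-yl, although the entering group has more heavy atoms and a different ring size, so across these two compounds neither feature shows up in the read-out. No measurement at hand accounts for these differences.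

From the compounds shown here alone, what stays open is whether the high number of compound 1 goes with the formyl group itself or with the place it holds on the ring, as compound 1 and compound 4 differ in both. An unsubstituted phenyl, or a phenyl carrying a carboxylic acid, an amine or a nitrile, would help separate these two readings at this position on the shared core.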